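A few compounds are considered here, and "the series" means these few. Any claim that something is new, unique, unknown or untested is made for them only; others in the source may bear on it.

Measured compounds:
compound 1, `Cc1cc(C)c2c(O)cc(-c3ccc(Cl)cc3)nc2n1`, 4070 nM
compound 2, `Cc1ccnc2nc(-c3ccc(Cl)cc3)cc(O)c12`, 759 nM
compound 3, `COc1ccccc1-c1cc(O)c2cccnc2n1`, 39800 nM

These three were tested in a functional assay on MDA-MB-435 cells (Homo sapiens); on this read-out higher numbers stand for weaker inhibition of growth and lower numbers for stronger inhibition of growth. Compound 2 gives the lowest of the three numbers, and compound 3 the highest. Compound 1 and compound 2 differ in one place, (methyl in place of hydrogen on an aromatic carbon), and that change gave a 5.4-fold higher number from compound 2 to compound 1 (0.73 log units; beyond the scatter). Compound 3 carries a different group on its core and a core without the methyl of compound 2; how the two cores differ is not broken down here.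

The unmeasured compound 4, `COc1ccccc1-c1cc(O)c2cc(C)cnc2n1`, is reached from compound 3 by methyl in place of hydrogen on an aromatic carbon. For the measured compounds named here, this is the same kind of change as the one from compound 2 to compound 1, but not the same: in compound 1 the methyl sits next to the ring nitrogen and meta to a methyl group, while in compound 4 it sits two atoms from the ring nitrogen, with no other methyl on that ring. Going by the values given here, the earlier step made the number higher, and nothing among the three measured compounds points the other way, so a step in the same direction is expected, though its size is uncertain because of a 5.4-fold higher number from compound 2 to compound 1 (0.73 log units; beyond the scatter) being the only precedent and its place being different. Compound 4 is therefore estimated at 70000 nM, with a likely range from 20000 nM to 250000 nM, meaning an expected step of a 1.8-fold higher number from compound 3 to compound 4 (0.25 log units; within the scatter).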

Compound 4, concentration for 50% growth inhibition: 3020 nM
For compound 4 the middle estimate is 23-fold (1.37 log units) above the measured one, and the stated range ends above it.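

In this assay, methyl in place of hydrogen on an aromatic carbon gave a 13-fold lower number from compound 3 to compound 4 (1.12 log units; beyond the scatter), a large step, whereas the same kind of change had moved the number the opposite way on the other core, and the two steps clearly disagree: the same change on two cores in this assay, a 5.4-fold higher number (0.73 log units; beyond the scatter) from compound 2 to compound 1 and a 13-fold lower number (1.12 log units; beyond the scatter) from compound 3 to compound 4, 71-fold (1.85 log units) apart, beyond the scatter of two such steps This shows that, among these compounds, neither the size nor even the direction of this change carries over from one core to another, so the step measured on one pair gives no safe forecast for the other. It does not show what sets the two steps apart: the pairs differ in where the methyl sits, in the aryl group they carry and in the methyl already present in compound 2, and with a single pair for each case these differences cannot be separated.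

The compounds shown leave open whether a methyl two atoms from the ring nitrogen would also lower the number on the core bearing the chlorophenyl group, which would tell the place of the methyl apart from the aryl group. They also leave open whether an ethyl group, a chlorine atom or a methoxy group at that place would follow the methyl of compound 4.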